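The source may report more compounds than this note shows. Statements on the series, on what has been measured and on what is new or still open speak of the compounds shown alone.

Of the compounds shown here, three have been tested in a functional assay on CCRF-CEM cells (Homo sapiens), read by MTT assay, with a stated time of 72 h; on this read-out lower numbers stand for stronger inhibition and higher numbers for weaker inhibition. Compound 1 `COc1ncnc2c1c(I)cn2[C@@H]1O[C@H](CO)[C@@H](O)[C@H]1O` gives 1150 nM in this assay. Compound 2 `C#Cc1cn([C@@H]2O[C@H](CO)[C@@H](O)[C@H]2O)c2ncnc(OC)c12` gives in this assay only a limit, > 20000 nM. Compound 3 `Cc1ncnc2c1c(-c1cccs1)cn2[C@@H]1O[C@H](CO)[C@@H](O)[C@H]1O` likewise gives only a limit in this assay, > 20000 nM, so its true value is not known as a number. For the measured compounds named here, the one measured step, an at least 17-fold higher number from compound 1 to compound 2 (1.24 log units; beyond the scatter), concerns a different position from the one changed here, and it is notable that (the limit of > 20000 nM in this assay, at which 2 of the 3 values shown sit).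

Compound 4 `COc1ncnc2c1c(-c1cccs1)cn2[C@@H]1O[C@H](CO)[C@@H](O)[C@H]1O` differs from compound 3 in one place: methoxy in place of methyl on an aromatic carbon. Going by the values given here, no measured pair shows the effect of this exchange on its own, and compound 1, which carries the methoxy group, differs from compound 4 in a second place as well, so its value cannot be carried over directly.

With compound 3 sitting at a limit, the step to compound 4 can only be estimated from where the weak compounds cluster, and the expected step is an at least 1.6-fold lower number from compound 3 to compound 4 (0.22 log units; that floor lies within the scatter). Compound 4 is therefore expected to give about 12000 nM in this assay, somewhere between 2000 nM and 20000 nM, with a real chance that again only a limit is returned.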

Compound 4, half-maximal inhibitory concentration: 90 nM
Beside the measured number, compound 4's estimate is 130-fold (2.12 log units) above it; the whole stated range lies above it.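

In this assay, with thiophen-2-yl held fixed, methoxy in place of methyl on the carbon next to the ring nitrogen gives an at least 220-fold lower number from compound 3 to compound 4 (2.34 log units; beyond the scatter), so this small exchange on its own separates a compound with no measured potency from compound 4, the strongest of the four. Methoxy alone is not enough, however: with methoxy held fixed, thiophen-2-yl in place of iodo gives a 13-fold lower number from compound 1 to compound 4 (1.11 log units; beyond the scatter) and thiophen-2-yl in place of ethynyl gives an at least 220-fold lower number from compound 2 to compound 4 (2.34 log units; beyond the scatter), so the group at the second site also counts, and compound 2 stays weak despite carrying methoxy. Two of these steps start from a limit rather than a number, so their true size is unknown: the limit of > 20000 nM in this assay, at which 2 of the 4 values shown sit.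

The compounds shown leave open whether the gain belongs to methoxy in particular or would also appear with an ethoxy group, an amine or a chlorine on the same carbon. They also leave open whether thiophen-2-yl is needed at the second site, or whether a phenyl or furan-2-yl group there would pair with methoxy just as well.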